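Changing the Aryl Group of Compound 3

A few compounds are considered here, and "the series" means these few. Any claim that something is new, unique, unknown or untested is made for them only; others in the source may bear on it.

Compound 1 `Cc1nc(-c2ccccc2)c(C(=O)N2CCN(c3cccc(Cl)c3)CC2)o1`: 39.2 nM
Compound 2 `Cc1nc(-c2ccc(F)cc2)c(C(=O)N2CCN(c3cccc(Cl)c3)CC2)o1`: 40.1 nM
Compound 3 `COc1cccc(N2CCN(C(=O)c3oc(C)nc3-c3ccccc3F)CC2)c1`: 56.1 nM

In a functional assay on HL-60 cells (Homo sapiens) for inhibition, read by MTT assay, with a stated time of 72 h (a lower number here means a stronger inhibitor, a higher number a weaker inhibitor), compound 3 gives 56.1 nM, within the usual scatter of both other compounds. Compound 4 `COc1ccc(Cl)cc1N1CCN(C(=O)c2oc(C)nc2-c2ccccc2F)CC1` has 5-chloro-2-methoxyphenyl in place of 3-methoxyphenyl on an amine nitrogen in a ring. Within the data shown here, the only measured step, a 1.0-fold higher number from compound 1 to compound 2 (0.01 log units; within the scatter), lies within the scatter but changes a different place, so it offers little guidance. Among the measured compounds shown here, no measured step tests this change directly. A modest shift toward a higher number in this assay is tentatively expected, and the estimated step is a 1.6-fold higher number from compound 3 to compound 4 (0.21 log units; within the scatter). For compound 4 the expected value is 90 nM, with an estimated range from 25 nM to 320 nM.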

Compound 4, half-maximal inhibitory concentration: 153 nM
Estimate against measurement, compound 4: 1.7-fold (0.23 log units) below, and the stated range covers the measured number.
By their numbers in this assay, from the lowest: compounds 1, 2 and 3 (each within the scatter of the next); then compound 4.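

The aryl group on the amine nitrogen in a ring is a place where the number can move beyond the scatter: in this assay there is a 2.7-fold higher number from compound 3 to compound 4 (0.44 log units; beyond the scatter). Among these compounds, the only earlier step, at a different place, stayed within the scatter. Here 5-chloro-2-methoxyphenyl gives a weaker inhibitor than 3-methoxyphenyl, but nothing measured here offers an explanation for the shift.

From the compounds shown here alone, the change moves the methoxy group and adds chlorine together, so their separate contributions remain open. Also open, going by these compounds, is how a nitrile or an amine on this aryl ring would behave.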